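Carbamoyl for hydroxymethyl on a shared diaryl ether core

The source may hold more compounds than are shown below. What is called first, only, known or untested is meant among the compounds shown, and "the series" means these compounds.

Of the compounds shown here, three built on one diaryl ether core have been measured in an in vitro ADME assay on microsomes from liver (Homo sapiens) for metabolic stability, tested at 1 uM; on this read-out higher numbers stand for fast clearance and lower numbers for slow clearance. Compound 1 `Cc1cc(/C=C/C#N)cc(C)c1Oc1cc(Nc2ccc(C#N)cc2)c(N)cc1C(F)(F)F` gives 150 mL.min-1.g-1. Compound 2 `Cc1cc(CCC#N)cc(C)c1Oc1cc(Nc2ccc(C#N)cc2)c(N)cc1C(N)=O` gives 160 mL.min-1.g-1. Compound 3 `Cc1cc(/C=C/C#N)cc(C)c1Oc1cc(Nc2ccc(C#N)cc2)c(N)cc1CO` gives 230 mL.min-1.g-1. The three numbers sit close together: the step of a 1.5-fold higher number from compound 1 to compound 3 (0.19 log units; within the scatter) lies within the scatter, and the values of compound 2 and compound 3, which differ in two places, are likewise within the scatter of each other. On this showing compound 3 is not separated from either of its neighbours.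

Compound 4 `Cc1cc(/C=C/C#N)cc(C)c1Oc1cc(Nc2ccc(C#N)cc2)c(N)cc1C(N)=O` is the next step. It differs from compound 3 as follows: carbamoyl in place of hydroxymethyl on an aromatic carbon

Within the data shown here, only one measured step bears directly on a change at this aromatic carbon, the exchange of trifluoromethyl for hydroxymethyl, a 1.5-fold higher number from compound 1 to compound 3 (0.19 log units; within the scatter), and it did not move the number beyond the scatter. Compound 2 already carries the carbamoyl group and gives 160 mL.min-1.g-1, a value close to that of compound 3, though the two differ in a second place as well. The account therefore expects no step beyond the scatter in this assay, a 1.4-fold lower number from compound 3 to compound 4 (0.13 log units; within the scatter), and estimates that compound 4 gives 170 mL.min-1.g-1, between 100 mL.min-1.g-1 and 290 mL.min-1.g-1.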

Compound 4, intrinsic clearance in microsomes: 200 mL.min-1.g-1
Estimate against measurement, compound 4: 1.2-fold (0.07 log units) below, and the stated range covers the measured number.
By their numbers in this assay, from the lowest: compounds 1, 2, 4 and 3 (each within the scatter of the next).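

With compound 4, the shared core with the 2-cyanoethenyl group now carries three different groups on this aromatic carbon, and none of the exchanges among them leaves the scatter in this assay: carbamoyl in place of hydroxymethyl gives (a 1.2-fold lower number from compound 3 to compound 4 (0.06 log units; within the scatter)), and carbamoyl in place of trifluoromethyl gives (a 1.3-fold higher number from compound 1 to compound 4 (0.12 log units; within the scatter)). Among these compounds, compound 4 also provides the first single-place reading of the other site of variation, where 2-cyanoethenyl in place of 2-cyanoethyl, with carbamoyl held constant, gives (a 1.3-fold higher number from compound 2 to compound 4 (0.10 log units; within the scatter)), so this change likewise does not separate the two compounds. Nothing presented here accounts for how closely these numbers lie together.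

From the compounds shown here alone, whether an amine, a carboxylic acid or a longer chain on this aromatic carbon would take the number outside the scatter remains open. Going by these compounds, it is also open whether carbamoyl, hydroxymethyl and trifluoromethyl would stay this close together if the 2-cyanoethyl group replaced 2-cyanoethenyl throughout.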